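Trifluoromethyl for Fluoro on the Central Ring

The compounds below may be only part of what the source reports. "The series", "measured", "known", "first", "only" and "open" are said of these compounds alone.

Three compounds share a core of two amide-linked aryl groups and have been tested in an assay on isolated protein for inhibition of Rho-associated protein kinase 1 (Homo sapiens), read by scintillation counting, radiometric assay and 33P incorporation, with a stated time of 40 min, in the presence of a further agent that is not named here; on this read-out higher numbers stand for weaker inhibition and lower numbers for stronger inhibition. Compound 1 `COc1cc(OCC(=O)Nc2cccc(NC(=O)c3ccc(N(C)C)cc3)c2)ccc1C=O` gives 3740 nM. Compound 2 `Cc1cc(C(=O)Nc2cccc(NC(=O)COc3ccc4c(=O)ccoc4c3)c2)no1` gives 68 nM. Compound 3 `CN(C)c1ccc(C(=O)Nc2cc(F)cc(NC(=O)COc3ccc4c(=O)ccoc4c3)c2)cc1` gives 49 nM; the gap between compound 3 and compound 2 lies within the scatter, so no order between them can be claimed, while the gap between compound 3 and compound 1 lies well beyond it.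

Compound 4 `CN(C)c1ccc(C(=O)Nc2cc(NC(=O)COc3ccc4c(=O)ccoc4c3)cc(C(F)(F)F)c2)cc1` has not yet been measured in this assay. It differs from compound 3 in a single place: trifluoromethyl in place of fluoro on an aromatic carbon. Among the compounds with values here, no pair of measured compounds shows this particular exchange, so no step can be drawn from the data. Given that the change is small and sits on the central ring, a step of modest size is expected, leaning toward a slightly higher number but not clearly beyond the scatter. On that basis compound 4 is estimated at 90 nM, with a range from 30 nM to 300 nM, an expected step of a 1.8-fold higher number from compound 3 to compound 4 (0.26 log units; within the scatter).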

Compound 4, half-maximal inhibitory concentration: > 10000 nM
Compound 4: only a limit was reported; the forecaster's own chance of this, stated with the estimate: 3%; middle value at least 110-fold (2.04 log units) away from the limit.
By their numbers in this assay, from the lowest: compounds 3 and 2 (each within the scatter of the next); then compound 1. At a limit, above all of these: compound 4.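

Compound 3 showed only that fluoro on this aromatic carbon, meta to two large groups, goes with strong inhibition, at 49 nM in this assay. With trifluoromethyl in place of fluoro, the data give an at least 200-fold higher number from compound 3 to compound 4 (2.30 log units; beyond the scatter), so a single exchange at this position can carry the value from the lowest of the series to beyond the measured range. That step is a lower bound, since compound 4 stands at a limit of the assay and not at a number: the limit of > 10000 nM in this assay, at which 1 of the 4 values shown sits.

From the compounds shown here alone, it remains open how a methyl, a chlorine, a methoxy or an amine on this carbon would read, and so whether the loss sets in with any group larger than fluoro or only with trifluoromethyl. The compounds shown also offer no pair setting fluoro against hydrogen here, so what fluoro itself contributes stays unknown.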